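Swapping the fluorophenyl arm of compound 1 for a trifluoromethylphenyl

The source may hold more compounds than are shown below. What is called first, only, known or untested is meant among the compounds shown, and "the series" means these compounds.

Measured compounds:
compound 1 `Oc1cccc(-c2cc(-c3ccccc3F)cc(-c3ccccc3O)n2)c1`: 24200 nM
compound 2 `Oc1ccc(-c2cc(-c3ccccc3F)cc(-c3ccccc3O)n2)cc1`: > 50000 nM
compound 3 `Oc1ccc(-c2cc(-c3ccccc3F)cc(-c3cccc(O)c3)n2)cc1`: 6370 nM

In a functional assay on T47D cells (Homo sapiens) for inhibition (a lower number here means a stronger inhibitor, a higher number a weaker inhibitor), compound 1 gives 24200 nM. Of the two actual numbers available, compound 1 has the higher one; the nearest, compound 3, is reached by a 3.8-fold lower number from compound 1 to compound 3 (0.58 log units; beyond the scatter). For compound 2 the result is a limit of the assay, > 50000 nM, and no number is known (the limit of > 50000 nM in this assay, at which 1 of the 3 values shown sits). Compound 4 `Oc1cccc(-c2cc(-c3ccc(C(F)(F)F)cc3)cc(-c3ccccc3O)n2)c1` differs from compound 1 in one place: 4-(trifluoromethyl)phenyl in place of 2-fluorophenyl on an aromatic carbon. For the measured compounds named here, none of the measured steps bears on this change; each of them, an at least 2.0-fold higher number from compound 1 to compound 2 (0.31 log units; beyond the scatter), a 3.8-fold lower number from compound 1 to compound 3 (0.58 log units; beyond the scatter) and an at least 7.8-fold lower number from compound 2 to compound 3 (0.89 log units; beyond the scatter), moves a hydroxyl around a hydroxyphenyl group while the 2-fluorophenyl stays fixed. The data therefore give no ground for expecting a shift in either direction, so the step of a 1.0-fold higher number from compound 1 to compound 4 (0.01 log units; within the scatter) is estimated to stay within the scatter. Compound 4 is accordingly expected to give about 25000 nM in this assay, between 7000 nM and 50000 nM.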

Compound 4, half-maximal inhibitory concentration: > 50000 nM
Compound 4 was reported as a limit; the forecaster's own chance of this, stated with the estimate: 30%; middle value at least 2.0-fold (0.30 log units) from the limit.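

In this assay, for the compounds shown here, the change gives an at least 2.0-fold higher number from compound 1 to compound 4 (0.31 log units; beyond the scatter), so the aryl group opposite the ring nitrogen does matter; the earlier compounds all kept 2-fluorophenyl there and could not show this. For compound 4, > 50000 nM is a limit of the assay and not a number. The full size of the step cannot be read because compound 4 sits at a limit: the limit of > 50000 nM in this assay, at which 2 of the 4 values shown sit.

Going by these compounds, the change swaps the fluorine substituent for trifluoromethyl and moves it on the phenyl ring at the same time, so 2-(trifluoromethyl)phenyl and 4-fluorophenyl remain open as the compounds that would separate the two. Also open, on these data alone, is how an unsubstituted phenyl, an amine or a carboxylic acid on that phenyl ring would fare at this position.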